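This account rests on a few compounds, and the source may have more. Where it says the series, first, only, none or still open, it means among the compounds named here.

Measured so far in a functional assay, read by fluorescence and spectrophotometry, with a stated time of 1 h; on this read-out higher numbers stand for an effect only at larger amounts of compound and lower numbers for an effect already at smaller amounts:
Compound 1 `O=S(=O)(/C=C/c1ccc(O)c(O)c1)CC1CCC1` gives 8800 nM.
Compound 2 `CCCCCCS(=O)(=O)/C=C/c1ccc(O)c(O)c1` gives 7300 nM.

Within the data shown here, compound 2 holds the lower of the two numbers, yet the single step to it, a 1.2-fold lower number from compound 1 to compound 2 (0.08 log units; within the scatter), lies within the scatter, so no order between the two is claimed. Compound 3 `O=S(=O)(/C=C/c1ccc(O)c(O)c1)CCCC1CCCC1` differs from compound 2 by cyclopentyl in place of propyl on a saturated chain carbon, three bonds along the chain from a sulfonyl sulfur. Among the measured compounds shown here, the one measured step exchanged a ring for a chain on the carbon bound to the sulfonyl sulfur and left the number essentially unchanged; the present change brings a ring in at a carbon three bonds along the chain from the sulfonyl sulfur, a place for which no measured step exists. Expected: a 1.0-fold lower number from compound 2 to compound 3 (0.02 log units; within the scatter), nothing beyond the scatter. Compound 3 is accordingly estimated at 7000 nM, between 3500 nM and 14000 nM.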

Compound 3, half-maximal effective concentration: 6300 nM
Estimate against measurement, compound 3: 1.1-fold (0.05 log units) above; measured number inside the range.
By their numbers in this assay, from the lowest: compounds 3, 2 and 1 (each within the scatter of the next).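

Cyclopentyl in place of propyl on a saturated chain carbon, three bonds along the chain from a sulfonyl sulfur, gives a 1.2-fold lower number from compound 2 to compound 3 (0.06 log units; within the scatter) in this assay and so brings the first measured ring at this place without separating the compounds. The remaining step reads a 1.4-fold lower number from compound 1 to compound 3 (0.15 log units; within the scatter) and likewise leaves the pair unresolved. No supporting data bear on this result. From the compounds shown here alone, how an amine or a carboxylic acid at the end of the chain would read in this assay remains open.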